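The compounds below may be only part of what the source reports. "The series", "measured", "known", "first", "only" and "open" are said of these compounds alone.

Measured so far:
compound 1, `CCCCc1cnc(Cc2ccc(-c3ccccc3C(=O)O)cc2)[nH]1` — > 10000 nM in an in vitro functional assay on cells for agonist activity at Bombesin receptor subtype-3 (Mus musculus), read by luminescence and calcium flux; on this read-out higher numbers stand for an effect only at larger amounts of compound and lower numbers for an effect already at smaller amounts
compound 2, `Cc1ccccc1Cc1cnc(CCc2ccc(-c3ccccc3C(=O)O)cc2)[nH]1` — 9.3 nM in this assay

For compound 1 the value given is a limit of this assay, not a number (the limit of > 10000 nM in this assay, at which 1 of the 2 values shown sits). Among the measured compounds shown here, compound 2 therefore stands as the only compound with a measured number in this assay, at 9.3 nM. Compound 3, `CC(C)(C)Cc1cnc(CCc2ccc(-c3ccccc3C(=O)O)cc2)[nH]1`, differs from compound 2 by one change: tert-butyl in place of 2-methylphenyl on a saturated chain carbon bound to an aromatic carbon. For the measured compounds named here, no measured pair shows such a step. The change from compound 2 to compound 3 is expected to weaken the effect in this assay beyond the scatter, by about a 16-fold higher number from compound 2 to compound 3 (1.21 log units; beyond the scatter). Compound 3 is estimated at 150 nM in this assay, within 20 nM to 2000 nM.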

Compound 3, half-maximal effective concentration: 6.3 nM
Compound 3: the middle estimate sits 24-fold (1.38 log units) above what was measured, outside the stated range (below it).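

In this assay, the two groups are interchangeable on a saturated chain carbon bound to an aromatic carbon, with the step reading a 1.5-fold lower number from compound 2 to compound 3 (0.17 log units; within the scatter). Compound 3 thus shows that a ring is not required at this place for an effect at low concentration, as tert-butyl has none where 2-methylphenyl has one. Nothing measured here gives a reason for this step. On these data alone, whether an amine, a hydroxyl group or a longer alkyl chain at this place would keep the effect remains open, as does the outcome with a smaller group such as methyl.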